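The source may report more compounds than this note shows. Statements on the series, on what has been measured and on what is new or still open speak of the compounds shown alone.

Measured compounds in this set:

- compound 1, `Cc1nn([C@H](C)c2ccc(Cl)cc2Cl)c2nc(N3CC[C@H](N4CCCCCC4)[C@H](C)C3)cnc12`: 23 nM
- compound 2, `Cc1nn([C@H](C)c2ccc(Cl)cc2Cl)c2nc(N3CC[C@H](N4CCCC4)[C@H](C)C3)cnc12`: 69 nM
- compound 3, `Cc1nn([C@H](C)c2ccc(Cl)cc2Cl)c2nc(N3CC[C@H](N4CCCCC4)[C@H](C)C3)cnc12`: 42 nM

All three share one core and differ only in the saturated nitrogen ring attached to the six-membered ring. In a functional assay on cells for antagonist activity at C-C chemokine receptor type 4 (Homo sapiens), read by fluorescence and calcium flux, with stated times of 2.5 s and 45 s (on this read-out lower numbers stand for stronger inhibition and higher numbers for weaker inhibition), compound 3 stands second highest of the three numbers; its nearest neighbour is compound 2, and a 1.6-fold lower number from compound 2 to compound 3 (0.22 log units; within the scatter), while a 1.8-fold higher number from compound 1 to compound 3 (0.26 log units; within the scatter). Among the compounds with values here, the single step beyond the scatter is a 3.0-fold higher number from compound 1 to compound 2 (0.48 log units; beyond the scatter).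

Compound 4, `Cc1nn([C@H](C)c2ccc(Cl)cc2Cl)c2nc(N3CC[C@H](N4CCC4)[C@H](C)C3)cnc12`, has not been measured. It differs from compound 3 by azetidin-1-yl in place of piperidin-1-yl on a saturated ring carbon. Within the data shown here, the steps that bear on this change are those from azepan-1-yl to pyrrolidin-1-yl and to piperidin-1-yl, and from pyrrolidin-1-yl to piperidin-1-yl: a shrinking ring has so far gone with a higher number, though only one of these steps is beyond the scatter. A further shrink to azetidin-1-yl is therefore expected to give a modest rise, a 2.6-fold higher number from compound 3 to compound 4 (0.42 log units; beyond the scatter), in this assay. For compound 4 the estimate in this assay is 110 nM, with a range from 45 nM to 270 nM.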

Compound 4, half-maximal inhibitory concentration: 58 nM
Compound 4: the middle estimate sits 1.9-fold (0.28 log units) above what was measured; low and high end bracket the measured number.
By their numbers in this assay, from the lowest: compounds 1, 3, 4 and 2 (each within the scatter of the next, the first and the last beyond it).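

In this assay, the link between a shrinking ring and a higher number does not extend to azetidin-1-yl: the steps are a 1.4-fold higher number from compound 3 to compound 4 (0.14 log units; within the scatter) and a 1.2-fold lower number from compound 2 to compound 4 (0.08 log units; within the scatter), so the four-membered ring cannot be told apart from the six-membered or five-membered ring at this position. Azepan-1-yl is now separated from two of the smaller rings, with the new step being a 2.5-fold higher number from compound 1 to compound 4 (0.40 log units; beyond the scatter), although compound 3 remains within the scatter of compound 1, so the series shows a shallow dependence on ring size rather than a steady progression. No measurement in hand accounts for this flat response to ring size.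

Still open, as far as these compounds go, is whether an open-chain amine such as dimethylamino, or a ring with a second hetero atom such as morpholin-4-yl, would hold the number in this range. The compounds shown also leave open whether a primary amine or a carboxylic acid would be accepted at this position.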